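The compounds below may be only part of what the source reports. "The series", "measured", "known", "first", "only" and "open" are said of these compounds alone.

Of the compounds shown here, two have been measured in an assay on HEK293 cells for positive allosteric modulation of metabotropic glutamate receptor 2 (Rattus norvegicus), read by thallium flux, with a stated time of 2.5 min; on this read-out higher numbers stand for an effect only at larger amounts of compound and lower numbers for an effect already at smaller amounts. Compound 1, `Cc1c(OCCCCOc2ccc(C(=O)O)cc2F)ccc(C(=O)CC2CCCC2)c1O`, gives 639 nM. Compound 2, `CC(=O)c1ccc(OCCCCOc2ccc(F)c(C(=O)O)c2)c(C)c1O`, gives 259 nM, the lowest of the two numbers; compound 1 stands well apart from it, beyond the usual scatter. Compound 1 and compound 2 differ in more than one place, so their gap cannot be tied to a single change. Compound 3, `Cc1c(OCCCCOc2ccc(F)c(C(=O)O)c2)ccc(C(=O)CC2CCCC2)c1O`, has not yet been measured. It differs from compound 2 in one place: cyclopentyl in place of hydrogen on a saturated chain carbon bound to a carbonyl carbon. Going by the values given here, no measured pair shows this change on its own, so the expectation leans on the single comparison available. A modest step in the direction of smaller numbers is expected, a 1.7-fold lower number from compound 2 to compound 3 (0.24 log units; within the scatter), though a result within the scatter of compound 2 would not surprise. Compound 3 is estimated at 150 nM, with a range from 50 nM to 500 nM.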

Compound 3, half-maximal effective concentration: 699 nM
Estimate against measurement, compound 3: 4.7-fold (0.67 log units) below; measured number outside the range, above it.
By their numbers in this assay, from the lowest: compound 2; then compounds 1 and 3 (each within the scatter of the next).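

In this assay, this assay, cyclopentyl in place of hydrogen on a saturated chain carbon bound to a carbonyl carbon now has a pair of its own, and the change goes against smaller numbers: a 2.7-fold higher number from compound 2 to compound 3 (0.43 log units; beyond the scatter). With cyclopentylmethyl carbonyl present in both compounds, 3-carboxy-4-fluorophenyl in place of 4-carboxy-2-fluorophenyl on an oxygen on a saturated carbon gives no separation, with a 1.1-fold higher number from compound 1 to compound 3 (0.04 log units; within the scatter). Nothing measured alongside these numbers explains either step.

On these data alone, whether an ethyl group or a phenyl ring in place of the cyclopentyl would give a number nearer that of compound 2 remains open. As far as these compounds go, it is also open whether the swap of the two carboxy-fluorophenyl groups would stay without effect on a compound carrying the acetyl group of compound 2.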